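Removing the Isopropyl from a Cyclic Urea

The compounds below may be only part of what the source reports. "The series", "measured", "known", "first", "only" and "open" are said of these compounds alone.

Three compounds share a core built from a piperidine-linked indole and a cyclic urea. In an assay on cell membranes for displacement of a labelled ligand from Adrenergic receptor alpha-1 (Rattus norvegicus) (on this read-out higher numbers stand for weaker inhibition and lower numbers for stronger inhibition), compound 1 `Cc1ccc2c(C3CCN(CCN4CCNC4=O)CC3)cn(-c3ccc(F)cc3)c2c1` gives 24 nM, compound 2 `O=C1NCCN1CCN1CCC(c2cn(-c3ccc(F)cc3)c3cc(Cl)ccc23)CC1` gives 9.6 nM, and compound 3 `CC(C)N1CCN(CCN2CCC(c3cn(-c4ccc(F)cc4)c4cc(C(F)(F)F)ccc34)CC2)C1=O` gives 91 nM. Among the compounds with values here, the only single-point step among them, a 2.5-fold lower number from compound 1 to compound 2 (0.40 log units; beyond the scatter), concerns the aromatic substituent and says nothing about the urea nitrogen. Compound 3 stands highest of the three: its number lies a clear distance above compound 1 and further still above compound 2, yet it differs from both at two places at once, the trifluoromethyl and the isopropyl, so neither change can be credited alone.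

Compound 4 `O=C1NCCN1CCN1CCC(c2cn(-c3ccc(F)cc3)c3cc(C(F)(F)F)ccc23)CC1` removes one of these differences: hydrogen in place of isopropyl on an amide-type nitrogen in a ring. Within the data shown here, no measured step bears directly on this change. Compounds 1 and 2, which carry the unsubstituted cyclic urea, both give lower numbers than compound 3, which is the only hint available, and it is confounded by the aromatic substituent. The account therefore expects compound 4 to move toward those two, with a step of a 2.6-fold lower number from compound 3 to compound 4 (0.41 log units; beyond the scatter) in this assay, but with wide uncertainty. For compound 4 the estimate is 35 nM, within a range from 10 nM to 120 nM.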

Compound 4, half-maximal inhibitory concentration: 33 nM
For compound 4 the middle estimate is 1.1-fold (0.03 log units) above the measured one; low and high end bracket the measured number.
By their numbers in this assay, from the lowest: compound 2; then compounds 1 and 4 (each within the scatter of the next); then compound 3.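

Within the data shown here, with the trifluoromethyl held in place, the isopropyl on the ring nitrogen can now be read alone: in this assay, hydrogen in its place gives a 2.8-fold lower number from compound 3 to compound 4 (0.44 log units; beyond the scatter), so this change by itself moves the number beyond the scatter, which no earlier pair could show. Among these compounds, compound 4 also gives the first reading of the aromatic substituent with trifluoromethyl on the unsubstituted cyclic urea, and the two comparisons differ: against chloro the step is a 3.4-fold higher number from compound 2 to compound 4 (0.54 log units; beyond the scatter), which lies beyond the scatter, while against methyl it is a 1.4-fold higher number from compound 1 to compound 4 (0.14 log units; within the scatter), which lies within it. No evidence here bears on why removing the isopropyl or changing the aromatic substituent has these effects.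

Going by these compounds, the isopropyl step is read only with trifluoromethyl on the aromatic carbon, so whether it holds at the same size with chloro or methyl there stays open. It also rests on a single pair of groups at this nitrogen, and the compounds shown do not tell where an ethyl, a cyclopropyl or an acetyl group on that nitrogen would fall.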